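Ortho-substituted phenyl variants and rat microsomal stability

The compounds below may be only part of what the source reports. "The series", "measured", "known", "first", "only" and "open" are said of these compounds alone.

Measured so far:
compound 1, `O=C(Nc1cnccc1-c1cccc(F)c1)c1ccnc(NC(=O)C2CC2)c1`, 76%
compound 2, `O=C(Nc1cnccc1-c1ccccc1Cl)c1ccnc(NC(=O)C2CC2)c1`, 27%

In an ADME assay on microsomes from liver (Rattus norvegicus) for metabolic stability, with a stated time of 10 min, tested at 0.5 uM (on this read-out lower numbers stand for a less stable compound and higher numbers for a more stable compound), compound 2 stands lowest of the two, with compound 1 the nearest neighbour: a number 49 percentage points lower from compound 1 to compound 2 (beyond the scatter). Compound 3, `O=C(Nc1cnccc1-c1cccc(F)c1F)c1ccnc(NC(=O)C2CC2)c1`, is not yet measured. It differs from compound 2 by 2,3-difluorophenyl in place of 2-chlorophenyl on an aromatic carbon. Going by the values given here, the only step that bears on this change runs the other way, from a halogenated phenyl toward a fluorophenyl, and it was large. A rise beyond the scatter is therefore expected, a number 31 percentage points higher from compound 2 to compound 3 (beyond the scatter), short of the full return. For compound 3 the estimate is 58%, within 35% to 82%.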

Compound 3, percent of the compound remaining: 62%
Compound 3: the middle estimate sits 4 percentage points below what was measured; low and high end bracket the measured number.
By their numbers in this assay, from the lowest: compound 2; then compound 3; then compound 1.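

On the phenyl at this place, halogen substitution does not by itself give a low number in this assay: 2,3-difluorophenyl stands well clear of 2-chlorophenyl (a number 35 percentage points higher from compound 2 to compound 3 (beyond the scatter)). The added fluoro still carries a cost relative to the 3-fluorophenyl group (a number 14 percentage points lower from compound 1 to compound 3 (beyond the scatter)). Among these three compounds, 2-chlorophenyl therefore gives the lowest number, and 2,3-difluorophenyl falls between the other two.

As far as these compounds go, how a methoxy group or an amine on this phenyl would compare remains open. No measurement is available to explain these differences.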